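Cytotoxicity series: oxadiazole to benzodioxin swap

The compounds below may be only part of what the source reports. "The series", "measured", "known", "first", "only" and "open" are said of these compounds alone.

Compound 2 `Cc1nnc(-c2cccc(-c3ccc(C(=O)N(Cc4cccc(OCCCCCC(=O)O)c4)C(C)C)cc3)c2)o1` is one of two measured members of the series. In an ADME assay on Raji cells (Homo sapiens) for cytotoxicity, read by CellTiter-Glo and resazurin assay, with a stated time of 72 h (a lower number here means that less compound is needed, a higher number that more compound is needed for the effect), compound 2 gives > 26000 nM, which is a limit of the assay rather than a number. Compound 1 `CC(=O)c1cccc(-c2ccc(C(=O)N(Cc3cccc(OCCCCCC(=O)O)c3)C(C)C)cc2)c1` carries acetyl where compound 2 carries 5-methyl-1,3,4-oxadiazol-2-yl. In this assay compound 1 gives > 26000 nM, again a limit. The step that the two limits leave unreadable from compound 1 to compound 2 is thus not readable, since both values sit at the limit of > 26000 nM in this assay, at which 2 of the 2 values shown sit.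

Compound 3 `CC(C)N(Cc1cccc(OCCCCCC(=O)O)c1)C(=O)c1ccc(-c2ccc3c(c2)OCCO3)cc1` is not yet measured. It differs from compound 2 by 2,3-dihydro-1,4-benzodioxin-6-yl in place of 3-(5-methyl-1,3,4-oxadiazol-2-yl)phenyl on an aromatic carbon. Among the compounds with values here, no measured step bears directly on this change, and the single step in hand, from compound 1 to compound 2, cannot be read. Nothing in the measured values points to a shift beyond the scatter, so the expected step is a step that the limit leaves unreadable from compound 2 to compound 3. Compound 3 is estimated at 40000 nM, with a range from 15000 nM to 120000 nM, and most likely only a limit will be reported.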

Compound 3, half-maximal effective concentration: > 21900 nM
Compound 3 was reported as a limit; the forecaster's own chance of this, stated with the estimate: 85%; the middle value does not contradict the limit.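

In this assay compound 3 gives > 21900 nM, which is a limit. Within the data shown here, with compound 1, compound 2 and compound 3 all standing only as limits, no step among them can be read. The compounds shown leave open whether exchanging the aromatic group changes the response in this assay at all.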